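This account rests on a few compounds, and the source may have more. Where it says the series, first, only, none or still open, it means among the compounds named here.

Measured compounds:
- compound 1 `O=c1[nH]cc(S(=O)(=O)Nc2ccccc2-c2cn(-c3cccc(F)c3)nn2)c(=O)[nH]1`; in a functional assay on A549 cells (Homo sapiens) for antiproliferative activity, read by MTT assay, with a stated time of 24 h (a higher number here means a weaker inhibitor, a lower number a stronger inhibitor), compound 1 gives 8130 nM
- compound 2 `O=c1[nH]cc(S(=O)(=O)Nc2cccc(-c3cn(-c4ccc(F)cc4)nn3)c2)c(=O)[nH]1`; for compound 2 this assay reports only a limit, > 20000 nM
- compound 3 `O=c1[nH]cc(S(=O)(=O)Nc2ccc(-c3cn(-c4ccccc4)nn3)cc2)c(=O)[nH]1`; in this assay compound 3 gives 7170 nM

Compound 3 and compound 1 sit within the scatter of each other, so no order between them can be read from these two numbers. Compound 2 stands apart only as a limit (the limit of > 20000 nM in this assay, at which 1 of the 3 values shown sits), not as a number.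

The next compound, compound 4 `O=c1[nH]cc(S(=O)(=O)Nc2ccc(-c3cn(-c4ccccc4Cl)nn3)cc2)c(=O)[nH]1`, differs from compound 3 in one place: chloro in place of hydrogen on an aromatic carbon, on an aromatic carbon of a six-membered aromatic ring of carbon only, ortho to a large group; one bond further out this reads phenyl to 2-chlorophenyl. For the measured compounds named here, no measured pair in this small set carries the same change, so there is no step to lean on. The expectation for this assay is a step of a 1.0-fold lower number from compound 3 to compound 4 (0.01 log units; within the scatter), that is, nothing beyond the scatter in either direction. Compound 4 is accordingly expected to give about 7000 nM, with a range from 2500 nM to 20000 nM.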

Compound 4, half-maximal inhibitory concentration: 2810 nM
The estimate for compound 4 lay 2.5-fold (0.40 log units) above the measured number; the measured number falls inside the stated range.
By their numbers in this assay, from the lowest: compound 4; then compounds 3 and 1 (each within the scatter of the next). At a limit, above all of these: compound 2.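

In this assay, for the compounds shown here, phenyl to 2-chlorophenyl gives a 2.6-fold lower number from compound 3 to compound 4 (0.41 log units; beyond the scatter), the only single-place step in this set and a modest one. This aromatic carbon, ortho to a large group, therefore responds to substitution: one chlorine atom, bringing no ring, no hydrogen-bond donor or acceptor and no net charge, moves the number beyond the scatter. Nothing measured here bears on why the step occurs.

From the compounds shown here alone, whether the step belongs to chloro alone stays open, and a methyl, a methoxy or an amine on this same carbon would help to settle that. Also open, going by these compounds, is whether the same change would carry over to compound 1 and compound 2, which differ from compound 3 in more than one place.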